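Swapping the aryl group on the hydrazone carbon

A few compounds are considered here, and "the series" means these few. Any claim that something is new, unique, unknown or untested is made for them only; others in the source may bear on it.

For the measured compounds named here, compound 3 `COc1ccc(/C=N/NC(=O)c2sc(N(C)C(=O)NC(=O)c3c(F)cccc3F)nc2C)cc1` is the one member of this small set with a number: in a functional assay on HepG2 cells (Homo sapiens) for inhibition, read by MTT assay, with a stated time of 72 h (on this read-out lower numbers stand for stronger inhibition and higher numbers for weaker inhibition), compound 3 gives 22.7 ug/mL. Compound 1 `Cc1nc(N(C)C(=O)NC(=O)c2c(F)cccc2F)sc1C(=O)N/N=C/c1ccc(Cl)cc1` sits at a limit of this assay, > 100 ug/mL. Compound 2 `Cc1nc(N(C)C(=O)NC(=O)c2c(F)cccc2F)sc1C(=O)N/N=C/c1ccccc1Cl` also sits at a limit, > 100 ug/mL. Compound 4 `Cc1nc(N(C)C(=O)NC(=O)c2c(F)cccc2F)sc1C(=O)N/N=C/c1ccccc1C(F)(F)F` is not yet measured; it differs from compound 3 by 2-(trifluoromethyl)phenyl in place of 4-methoxyphenyl on a carbon with a double bond to nitrogen. Going by the values given here, the steps that bear on this change ran the other way, from a chlorophenyl to the 4-methoxyphenyl: an at least 4.4-fold lower number from compound 2 to compound 3 (0.64 log units; beyond the scatter) and an at least 4.4-fold lower number from compound 1 to compound 3 (0.64 log units; beyond the scatter). Leaving the 4-methoxyphenyl for the 2-(trifluoromethyl)phenyl is therefore expected to raise the number, quite possibly reaching (the limit of > 100 ug/mL in this assay, at which 2 of the 3 values shown sit). The expected step is a 4.4-fold higher number from compound 3 to compound 4 (0.64 log units; beyond the scatter). For compound 4 the estimated value is 100 ug/mL, with a range from 30 ug/mL to 300 ug/mL.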

Compound 4, half-maximal inhibitory concentration: 1.11 ug/mL
Beside the measured number, compound 4's estimate is 90-fold (1.95 log units) above it; measured number outside the range, below it.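

For the compounds shown here, on the carbon with a double bond to nitrogen, the choice of aryl group can matter far more than the earlier compounds showed, with a 20-fold lower number from compound 3 to compound 4 (1.31 log units; beyond the scatter). Even with the ring substituent as the only change, trifluoromethyl in place of chloro gives an at least 90-fold lower number from compound 2 to compound 4 (1.95 log units; beyond the scatter), and the 4-chlorophenyl comparison gives an at least 90-fold lower number from compound 1 to compound 4 (1.95 log units; beyond the scatter). Compound 1 and compound 2 therefore remain limits rather than numbers: the limit of > 100 ug/mL in this assay, at which 2 of the 4 values shown sit.

On these data alone, whether a nitrile, an amine or a carboxylic acid on this aryl ring would give a similarly low number stays open. So does whether the trifluoromethyl group would do so elsewhere on the ring.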